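Series notes: amide variation on a shared bicyclic core

A few compounds are considered here, and "the series" means these few. Any claim that something is new, unique, unknown or untested is made for them only; others in the source may bear on it.

Measured so far:
compound 1 `CC(C)OC(=O)C1CN(C(=O)c2ccc(C#N)cc2)CC(C)(C)c2cc(C#N)[nH]c21` gives 91%
compound 2 `CC(C)OC(=O)C1=CN(C(=O)c2ccc(F)cc2)CC(C)(C)c2cc(C#N)[nH]c21` gives 119%

In an assay on HEK293 cells for agonist activity at Bile acid receptor (Homo sapiens), read by a luciferase reporter (on this read-out higher numbers stand for larger maximal responses and lower numbers for smaller maximal responses), compound 2 stands highest of the two numbers, with compound 1 lower by a gap beyond the scatter; the two compounds differ in more than one place, so only their values are known. Compound 3 `CC(C)OC(=O)C1=CN(C(=O)C2CCCCC2)CC(C)(C)c2cc(C#N)[nH]c21` has not been measured. It differs from compound 2 by cyclohexyl in place of 4-fluorophenyl on a carbonyl carbon. Going by the values given here, no measured pair shows this change, so the expectation is a step from compound 2 to compound 3 of modest size, downward or none beyond the scatter, a number 14 percentage points lower from compound 2 to compound 3 (beyond the scatter). For compound 3 the estimate is 105%, between 75% and 130%.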

Compound 3, largest response reached (reported as efficacy), in percent of the reference or control that the assay uses: 124%
Beside the measured number, compound 3's estimate is 19 percentage points below it, and the stated range covers the measured number.
By their numbers in this assay, from the lowest: compound 1; then compounds 2 and 3 (each within the scatter of the next).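

Going by these compounds alone, the step of a number 5 percentage points higher from compound 2 to compound 3 (within the scatter) in this assay is the only single-place comparison so far. For this pair, cyclohexyl serves on the carbonyl carbon as well as 4-fluorophenyl, so neither the aromatic ring nor the fluorine is needed to keep this response. Nothing available accounts for this result.

As far as these compounds go, whether an open chain such as n-butyl, or a piperidine with its ring amine, would keep the response at this carbonyl carbon remains open. Within the data shown here, compound 1 differs from compound 2 in more than one place, so no step between them can be read.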